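This account rests on a few compounds, and the source may have more. Where it says the series, first, only, none or still open, it means among the compounds named here.

Three compounds of the series carry numbers in a functional assay on PC-12 cells (Rattus norvegicus) for cytotoxicity, read by MTT assay, with stated times of 2 h and 24 h, tested at 1 uM; on this read-out lower numbers stand for a weaker effect and higher numbers for a stronger effect at the one concentration tested. Compound 1 `Oc1cc(C(F)(F)F)ccc1-c1nc(-c2ccccc2O)n(-c2ccc(F)cc2)n1` gives 67.2%. Compound 2 `Oc1cc(C(F)(F)F)ccc1-c1nc(-c2ccccc2O)n(-c2ccc(C(F)(F)F)cc2)n1` gives 70.7%. Compound 3 `COc1ccccc1-n1nc(-c2ccc(C(F)(F)F)cc2O)nc1-c1ccccc1O` gives 70.7%. Compound 3 stands level with compound 2 at the digits shown, the two together the highest of the three numbers; its nearest neighbour is compound 2, with no change at the digits printed from compound 2 to compound 3 (within the scatter), and its furthest is compound 1, with a number 3.5 percentage points higher from compound 1 to compound 3 (within the scatter). The remaining step, a number 3.5 percentage points higher from compound 1 to compound 2 (within the scatter), also lies within the scatter.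

Compound 4 `Oc1cc(C(F)(F)F)ccc1-c1nc(-c2ccccc2O)n(-c2cccc(Cl)c2)n1` has not yet been measured in this assay. It differs from compound 3 in one place: 3-chlorophenyl in place of 2-methoxyphenyl on an aromatic nitrogen. Within the data shown here, two measured steps bear on this change, since each replaces the group on the same aromatic nitrogen: a number 3.5 percentage points higher from compound 1 to compound 3 (within the scatter) and no change at the digits printed from compound 2 to compound 3 (within the scatter). Both lie within the scatter, so the read-out has so far been insensitive to which ring sits on that nitrogen, across 4-fluorophenyl, 4-(trifluoromethyl)phenyl and 2-methoxyphenyl. Among the measured compounds shown here, no measured compound carries 3-chlorophenyl, so the expectation rests on those two steps alone. From this, in this assay the expected step is a number 1.7 percentage points lower from compound 3 to compound 4 (within the scatter), none beyond the scatter. The estimate for compound 4 is 69%, with a range from 59% to 79%.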

Compound 4, a percentage reported as activity, at one concentration (the size of the read-out at that concentration, not a potency): 72.3%
The estimate for compound 4 lay 3.3 percentage points below the measured number, within the range that was stated.
By their numbers in this assay, from the lowest: compounds 1, 2, 3 and 4 (each within the scatter of the next).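

Working notes on the ring on the aromatic nitrogen: 3-chlorophenyl extends the set of tolerated rings in this assay to one carrying chlorine and substituted at the 3-position, and compound 4 stays within the scatter of every earlier compound (a number 1.6 percentage points higher from compound 3 to compound 4 (within the scatter); a number 1.6 percentage points higher from compound 2 to compound 4 (within the scatter); a number 5.1 percentage points higher from compound 1 to compound 4 (within the scatter)). Even the largest of these steps, the one from the 4-fluorophenyl compound, does not leave the scatter, so among these four compounds neither the kind of substituent on that ring nor its printed location (2-methoxy, 3-chloro, 4-fluoro or 4-trifluoromethyl) separates the numbers, and no compound shown goes against this. No measurement available here offers an explanation for this insensitivity.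

On these data alone, all four compounds keep a substituted phenyl ring on that nitrogen, so it remains open whether a ring bearing a carboxylic acid or a primary amine, or a saturated alkyl chain in place of the ring, would move the number beyond the scatter. Also open, as far as these compounds go, is what happens when the 2-hydroxyphenyl group or the other hydroxyl-bearing ring of the shared core is changed, for instance with methoxy in place of hydroxyl.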